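The source may report more compounds than this note shows. Statements on the series, on what has been measured and on what is new or still open speak of the compounds shown alone.

Measured compounds:

Compound 1, `O=[N+]([O-])c1cccc2c1CCN(c1ncnc3c1ncn3[C@@H]1O[C@H](CO)[C@@H](O)[C@H]1O)C2`: in an assay on isolated protein for binding affinity to Equilibrative nucleoside transporter 1 (Homo sapiens) (on this read-out higher numbers stand for weaker inhibition and lower numbers for stronger inhibition), compound 1 gives 3020 nM.
Compound 2, `Nc1nc(SCc2ccc(Br)cc2)c2ncn([C@@H]3O[C@H](CO)[C@@H](O)[C@H]3O)c2n1`: in this assay compound 2 gives 813 nM.

Among the compounds with values here, of the two numbers known so far, compound 2 has the lower one, and its gap to compound 1 is wide enough to lie beyond the scatter of repeated measurements, so compound 2 is the stronger inhibitor of the pair. Both compounds share a sugar bound to a purine-like core, and they differ in several places at once, so no single change can be read from that pair.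

Compound 3, `CCC(C)Sc1nc(N)nc2c1ncn2[C@@H]1O[C@H](CO)[C@@H](O)[C@H]1O`, has not yet been measured. Compared with compound 2 it carries sec-butyl in place of 4-bromobenzyl on a sulfur. The aromatic ring with its bromine is thus gone, and a short branched chain takes its place on the same sulfur. Within the data shown here, nothing among the measured compounds shows what this exchange does; no step of that kind has been seen here. The expectation for compound 3 is therefore a guess: a weaker inhibitor than compound 2, with a step from compound 2 to compound 3 of about a 4.9-fold higher number from compound 2 to compound 3 (0.69 log units; beyond the scatter). Compound 3 is estimated at 4000 nM, within a range of 1200 nM to 15000 nM.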

Compound 3, half-maximal inhibitory concentration: 63100 nM
Compound 3: the middle estimate sits 16-fold (1.20 log units) below what was measured, outside the stated range (above it).
By their numbers in this assay, from the lowest: compound 2; then compound 1; then compound 3.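

In this assay, the group on the sulfur turns out to matter a great deal: putting sec-butyl in place of 4-bromobenzyl gives a 78-fold higher number from compound 2 to compound 3 (1.89 log units; beyond the scatter), a large step toward weaker inhibition. Within the data shown here, this is the first comparison here in which only one place differs, so the loss can be tied to this exchange, which the earlier pair of compounds could not show. The exchange removes the aromatic ring and the bromine together and also introduces a branched chain, and no measurement here separates these parts or explains the loss.

On these data alone, it remains open whether the aromatic ring, the bromine or the branching accounts for most of the step; plain benzyl on the same sulfur would test the bromine, and a straight butyl chain would test the branching. Also open, as far as these compounds go, is how other groups at this place would behave, such as a phenethyl group, with a longer chain leading to the ring, or a benzyl group carrying a carboxylic acid or an amine.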